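The compounds below may be only part of what the source reports. "The series", "measured", "known", "first", "only" and "open" are said of these compounds alone.

Compound 1 `Cc1nc(N2CCN(C)CC2)c2nc(-c3ccccc3Cl)n(CCO)c2n1` gives 13%
Compound 2 `COCCn1c(-c2ccccc2Cl)nc2c(N3CCN(C(C)=O)CC3)nc(C)nc21` gives 35%

In an ADME assay (liver) for metabolic stability, with Liver microsome (Homo sapiens) as the target, read by LC-MS, using microsomes, with a stated time of 30 min, tested at 4 uM (on this read-out lower numbers stand for a less stable compound and higher numbers for a more stable compound), compound 1 gives 13% and so holds the lower of the two numbers, while compound 2 reaches 35% and sits higher by a gap beyond the usual scatter. Among the compounds with values here, no two measured compounds differ in one place only, so no single change has a measured effect yet. Compound 3 `Cc1nc(N2CCN(C)CC2)c2nc(-c3ccccc3Cl)n(C3CC3)c2n1` keeps the core of compound 1 but carries cyclopropyl in place of 2-hydroxyethyl on an aromatic nitrogen. With compound 1 starting at 13% there is more room to move up than down, so a small rise is expected, one that stays within the scatter. The estimated step is a number 7 percentage points higher from compound 1 to compound 3 (within the scatter) and remains a rough expectation. For compound 3 the expected value is 20% with an estimated range from 6% to 42% on repeated measurement.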

Compound 3, percent of the compound remaining: 31%
Compound 3: the middle estimate sits 11 percentage points below what was measured; the measured number falls inside the stated range.
By their numbers in this assay, from the lowest: compound 1; then compounds 3 and 2 (each within the scatter of the next).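

In this assay, within the data shown here, putting cyclopropyl in place of 2-hydroxyethyl on the aromatic nitrogen gives a number 18 percentage points higher from compound 1 to compound 3 (beyond the scatter), the first single change with a measured effect in this set. This shows that the group on this nitrogen matters for the percent of compound remaining, even though the two groups match in heavy atoms. Several features change together, as the ring arrives and the hydrogen-bond donor and acceptor leave, and no measurement here explains the rise.

As far as these compounds go, it remains open whether the rise follows the loss of the hydroxyl or the gain of the ring, which a plain ethyl group or a cyclobutyl group on the same nitrogen could help to separate. From the compounds shown here alone, whether the same swap gives a similar step with a different group in place of the methylpiperazine also remains open.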